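The compounds below may be only part of what the source reports. "The series", "measured", "known", "first", "only" and "open" are said of these compounds alone.

Series notes, step from compound 2 to compound 3.

Compound 1 `COc1cc(-c2nnc3n2NC(c2ccco2)C(C(=O)c2ccccc2F)S3)cc(OC)c1OC` carries a 2-fluorophenyl on the carbonyl carbon; in a functional assay on MCF7 cells (Homo sapiens) for cytotoxicity, read by MTT assay, with a stated time of 48 h (on this read-out lower numbers stand for stronger inhibition and higher numbers for weaker inhibition), compound 1 gives 94800 nM. Compound 2 `COc1cc(-c2nnc3n2NC(c2ccco2)C(C(=O)c2cccc4ccccc24)S3)cc(OC)c1OC` differs only there, naphthalen-1-yl in place of 2-fluorophenyl. In this assay compound 2 gives > 100000 nM, which is a limit of the assay and not a number. The step of an at least 1.0-fold higher number from compound 1 to compound 2 (0.02 log units; that floor lies within the scatter) therefore sets only a floor, and the limit of > 100000 nM in this assay, at which 1 of the 2 values shown sits, marks where compound 2 stands: no number beyond the limit is known.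

Compound 3 `COc1cc(-c2nnc3n2NC(c2ccco2)C(C(=O)c2ccc(F)c(F)c2)S3)cc(OC)c1OC` is the next point: 3,4-difluorophenyl in place of naphthalen-1-yl on a carbonyl carbon. This returns to a single fluorinated phenyl ring, nearer to compound 1 than to compound 2. Within the data shown here, the one measured step gives no direction for this change; what is expected from it in this assay is at most a small shift, an at least 1.1-fold lower number from compound 2 to compound 3 (0.04 log units; that floor lies within the scatter), not clearly beyond the scatter. Compound 3 is estimated at 90000 nM, within 40000 nM to 200000 nM, with a fair chance that only a limit is reported.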

Compound 3, half-maximal inhibitory concentration: 73200 nM
Beside the measured number, compound 3's estimate is 1.2-fold (0.09 log units) above it; measured number inside the range.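

In this assay, the step of a 1.3-fold lower number from compound 1 to compound 3 (0.11 log units; within the scatter) gives a second measured number for a fluorinated phenyl ring on the carbonyl carbon, and it shows that 3,4-difluorophenyl and 2-fluorophenyl cannot be told apart at this position. The step of an at least 1.3-fold lower number from compound 2 to compound 3 (0.13 log units; that floor lies within the scatter) is only a floor and does not clear the scatter, so no difference between 3,4-difluorophenyl and naphthalen-1-yl is established. Compound 2 remains a limit of the assay and not a number: the limit of > 100000 nM in this assay, at which 1 of the 3 values shown sits.

All three groups shown at this position are aromatic rings of carbon only, and no step among them lies beyond the scatter. As far as these compounds go, what an amine or a carboxylic acid on the phenyl ring, or a longer chain in place of that ring, would give in this assay remains open.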